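Benzothiophenyl in place of pyrazolyl: expected clearance of compound 4

The compounds below may be only part of what the source reports. "The series", "measured", "known", "first", "only" and "open" are said of these compounds alone.

Compound 2 `CC(C)n1cc(-c2cc(C(O)(C(F)(F)F)C(F)(F)F)cnc2N2CCN(S(=O)(=O)c3ccc(N)nc3)CC2)cn1` gives 38 mL.min-1.g-1 in an ADME assay (liver) for metabolic stability, with Liver microsome (Homo sapiens) as the target, using microsomes and NADPH, with a stated time of 30 min, tested at 1 uM (a higher number here means faster removal of the compound, a lower number slower removal), and stands highest of the two numbers measured in this series. Its nearest neighbour is compound 3 `Nc1ccc(S(=O)(=O)N2CCN(c3ncc(C(O)(C(F)(F)F)C(F)(F)F)cc3-c3cccc(F)c3)CC2)cn1`, which gives 25 mL.min-1.g-1, separated by a 1.5-fold lower number from compound 2 to compound 3 (0.18 log units; within the scatter). For compound 1 `Nc1ccc(S(=O)(=O)N2CCN(c3ncc(C(O)(C(F)(F)F)C(F)(F)F)cc3C#CC3CC3)CC2)cn1` the assay reports only a limit, not a number: < 14 mL.min-1.g-1. That limit is the limit of < 14 mL.min-1.g-1 in this assay, at which 1 of the 3 values shown sits. From compound 1 the steps were an at least 2.7-fold higher number from compound 1 to compound 2 (0.43 log units; beyond the scatter) and an at least 1.7-fold higher number from compound 1 to compound 3 (0.25 log units; that floor lies within the scatter).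

Compound 4 `Nc1ccc(S(=O)(=O)N2CCN(c3ncc(C(O)(C(F)(F)F)C(F)(F)F)cc3-c3ccc4sccc4c3)CC2)cn1` differs from compound 2 by 1-benzothiophen-5-yl in place of 1-isopropyl-1H-pyrazol-4-yl on an aromatic carbon. Within the data shown here, the one measured step that bears on this change, an aromatic ring taking the place of the 1-isopropyl-1H-pyrazol-4-yl group, is a 1.5-fold lower number from compound 2 to compound 3 (0.18 log units; within the scatter), which stayed within the scatter. The account therefore expects for compound 4 a step of a 1.1-fold higher number from compound 2 to compound 4 (0.02 log units; within the scatter), not beyond the scatter. Compound 4 is expected to give 40 mL.min-1.g-1 in this assay, with a range from 20 mL.min-1.g-1 to 80 mL.min-1.g-1.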

Compound 4, intrinsic clearance in microsomes: 48 mL.min-1.g-1
The estimate for compound 4 lay 1.2-fold (0.08 log units) below the measured number; measured number inside the range.
By their numbers in this assay, from the lowest: compounds 3, 2 and 4 (each within the scatter of the next). At a limit, below all of these: compound 1.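

In this assay, the position ortho to a large group takes the 1-benzothiophen-5-yl group with no step beyond the scatter from either earlier aromatic group: a 1.3-fold higher number from compound 2 to compound 4 (0.10 log units; within the scatter) and a 1.9-fold higher number from compound 3 to compound 4 (0.28 log units; within the scatter). Compounds 2, 3 and 4 thus all lie within the scatter of one another, although these aromatic groups differ in their ring types and hetero atoms. The step away from the 2-cyclopropylethynyl group, an at least 3.4-fold higher number from compound 1 to compound 4 (0.53 log units; beyond the scatter), joins an at least 2.7-fold higher number from compound 1 to compound 2 (0.43 log units; beyond the scatter) beyond the scatter, whereas an at least 1.7-fold higher number from compound 1 to compound 3 (0.25 log units; that floor lies within the scatter) goes against this pattern.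

Compound 1 gives a limit and not a number, so how far it lies from the others stays open: the limit of < 14 mL.min-1.g-1 in this assay, at which 1 of the 4 values shown sits.

Also open, on these data alone, is whether a non-aromatic group in this place, such as a morpholine or a simple amine, would fall with compound 1 or with compounds 2, 3 and 4.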